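Replacing Furan-2-yl with Thiophen-2-yl on a Shared Core

The source may report more compounds than this note shows. Statements on the series, on what has been measured and on what is new or still open speak of the compounds shown alone.

Compound 1 `O=c1[nH]/c(=C\c2ccccn2)c(=O)[nH]/c1=C\c1cccc(Oc2ccc(F)cc2)c1`: 49.1 nM
Compound 2 `O=c1[nH]/c(=C\c2cccc(Oc3ccc(F)cc3)c2)c(=O)[nH]/c1=C\c1ccccc1`: 389 nM
Compound 3 `O=c1[nH]/c(=C\c2ccco2)c(=O)[nH]/c1=C\c1cccc(Oc2ccc(F)cc2)c1`: 155 nM

These three compounds were compared in a functional assay on NCI-H460 cells (Homo sapiens) for cytotoxicity, read by MTT assay, with a stated time of 72 h; a lower number here means a stronger inhibitor, a higher number a weaker inhibitor. Compound 3 stands in the middle of the three, with 155 nM. Compound 2 lies above it and compound 1 below it, and both gaps are beyond the scatter.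

Compound 4 `O=c1[nH]/c(=C\c2cccs2)c(=O)[nH]/c1=C\c1cccc(Oc2ccc(F)cc2)c1` has not yet been measured. It departs from compound 3 by one exchange: thiophen-2-yl in place of furan-2-yl on a double-bonded chain carbon bound to an aromatic carbon. Going by the values given here, no measured step makes this exchange itself, so the evidence is indirect. Replacing pyridin-2-yl gave a 7.9-fold higher number from compound 1 to compound 2 (0.90 log units; beyond the scatter) with phenyl and a 3.2-fold higher number from compound 1 to compound 3 (0.50 log units; beyond the scatter) with furan-2-yl. The closest guide is the exchange between the two groups without pyridin-2-yl, a 2.5-fold lower number from compound 2 to compound 3 (0.40 log units; beyond the scatter). Furan-2-yl and thiophen-2-yl are both five-membered aromatic rings with 1 hetero atom, so a smaller step than any of these is expected, with no clear direction. The expected step is a 1.1-fold higher number from compound 3 to compound 4 (0.04 log units; within the scatter), which means none beyond the scatter. For compound 4 the estimated value is 170 nM, with an expected range from 70 nM to 400 nM.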

Compound 4, half-maximal inhibitory concentration: > 1000 nM
Compound 4 gave a limit, no number (the forecaster's own chance of this, stated with the estimate: 2%); middle value at least 5.8-fold (0.76 log units) from the limit.
By their numbers in this assay, from the lowest: compound 1; then compound 3; then compound 2. At a limit, above all of these: compound 4.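

In this assay compound 4 gave only a limit and no number: the limit of > 1000 nM in this assay, at which 1 of the 4 values shown sits. Even so, this exchange of one five-membered aromatic ring with 1 hetero atom for another, with sulfur in place of oxygen and the same counts of heavy atoms, donors and acceptors, gave an at least 6.4-fold higher number from compound 3 to compound 4 (0.80 log units; beyond the scatter), so this position distinguishes between two groups that these counts do not separate. Thiophen-2-yl also falls behind the other two groups, with an at least 2.5-fold higher number from compound 2 to compound 4 (0.41 log units; beyond the scatter) and an at least 20-fold higher number from compound 1 to compound 4 (1.30 log units; beyond the scatter), which places it at the weak end of this series and shows that the two five-membered rings do not stand together, since furan-2-yl gave a lower number than phenyl.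

From the compounds shown here alone, how far the true value of compound 4 lies past its limit remains open. Also open, going by these compounds, is what a ring holding both sulfur and nitrogen, such as thiazol-2-yl, or a pyridin-3-yl group would do at this place.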